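The compounds below may be only part of what the source reports. "The series", "measured", "known", "first", "only" and "open" are said of these compounds alone.

Notes on the series, around the step from compound 2 to compound 4.

Three compounds carry a measured value in a physicochemical assay for acid dissociation. Compound 1 `COc1cccc(Oc2ccc3c(NCCCNCc4cc(F)ccc4OC)ccnc3c2)c1` gives 9.28. Compound 2 `FC(F)(F)c1cc(-c2ccc3c(NCCCNCc4ccco4)ccnc3c2)cc(C(F)(F)F)c1` gives 9.47. Compound 3 `c1coc(CNCCCNc2ccnc3cc(CC4CCCCC4)ccc23)c1` gives 9.47. On the numbers shown, compound 2 is level with compound 3 at the digits printed, the two together sitting at the top of the three; the nearest is compound 3, with no change at the digits printed, and the furthest is compound 1, lower by an amount that stays within the scatter. Within the data shown here, no pair among the three differs in only one place, so no single-point step can be read off.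

Compound 4 `COc1cccc(CNCCCNc2ccnc3cc(-c4cc(C(F)(F)F)cc(C(F)(F)F)c4)ccc23)c1O` has not yet been measured in this assay. It differs from compound 2 by 2-hydroxy-3-methoxyphenyl in place of furan-2-yl on a saturated chain carbon bound to an amine nitrogen. Across the three measured compounds the group on that chain carbon varies, as does the group on the shared core, and the values stay close to one another. On that basis the step from compound 2 to compound 4 is expected to be small, a number 0.07 log units lower from compound 2 to compound 4 (within the scatter), with no confident direction and quite possibly within the scatter. Compound 4 is estimated at 9.4, within a range from 8.9 to 9.9.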

Compound 4, acid dissociation constant: 9.47
Compound 4: the middle estimate sits 0.07 log units below what was measured; the range from low to high includes it.
By their numbers in this assay, from the lowest: compounds 1, 2, 3 and 4 (each within the scatter of the next).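

The series now holds a step that differs in one place, at the saturated chain carbon bound to an amine nitrogen: in this assay, 2-hydroxy-3-methoxyphenyl in place of furan-2-yl gives no change at the digits printed from compound 2 to compound 4 (within the scatter) with the rest of the structure unchanged. Among these compounds, in the earlier compounds, the group on that carbon and the group on the shared core varied together, so neither could be read alone; here, an exchange from a five-membered aromatic ring with 5 heavy atoms and no hydrogen-bond donor to a six-membered aromatic ring with 9 heavy atoms and 1 hydrogen-bond donor leaves the read-out level at the digits printed. No measurement at hand offers an explanation for this level result.

As far as these compounds go, this is one exchange on one core, so whether the read-out also holds with a carboxylic acid or a dimethylamino group on that chain carbon stays open. Also open, from the compounds shown here alone, are the effect of a longer chain between the two nitrogens and whether the same exchange gives the same step with the core group of compound 1 or compound 3.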